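Swapping the aryl group on the carbonyl of a trimethoxyphenyl pyrazole chalcone

The source may hold more compounds than are shown below. What is called first, only, known or untested is meant among the compounds shown, and "the series" means these compounds.

Measured compounds:
- compound 1, `COc1cc(-c2cc(/C=C/C(=O)c3ccc(N)cc3)[nH]n2)cc(OC)c1OC`, with -83% in a functional assay on NCI-H522 cells (Homo sapiens) for cytotoxicity, read by sulforhodamine B assay, with a stated time of 48 h, tested at 100 uM; on this read-out higher numbers stand for a weaker effect at the one concentration tested and lower numbers for a stronger effect
- compound 2, `COc1cc(-c2cc(/C=C/C(=O)c3ccc(Cl)c(Cl)c3)[nH]n2)cc(OC)c1OC`, with -65% in this assay
- compound 3, `COc1ccc(C(=O)/C=C/c2cc(-c3cc(OC)c(OC)c(OC)c3)n[nH]2)cc1OC`, with -97% in this assay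

Compound 3 gives the lowest number of the three, so its effect at the single concentration is the strongest of this small set. Compound 4, `COc1cc(-c2cc(/C=C/C(=O)c3ccc(F)c(F)c3)[nH]n2)cc(OC)c1OC`, has not been measured yet. It differs from compound 3 in one place: 3,4-difluorophenyl in place of 3,4-dimethoxyphenyl on a carbonyl carbon.

The step that bears most directly on this change is a number 32 percentage points lower from compound 2 to compound 3 (beyond the scatter), where two chlorine atoms on that ring gave way to two methoxy groups. The new compound carries two fluorine atoms on the same ring, a halogen pattern resembling compound 2 rather than compound 3. The reverse of that step is therefore the natural guide, and the two other steps, a number 18 percentage points higher from compound 1 to compound 2 (beyond the scatter) and a number 14 percentage points lower from compound 1 to compound 3 (beyond the scatter), also place the halogenated ring at the weaker end. A rise of moderate size, a number 22 percentage points higher from compound 3 to compound 4 (beyond the scatter), is therefore expected in this assay. Compound 4 is estimated at -75%, within a range from -95% to -55%.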

Compound 4, a percentage reported as activity, at one concentration (the size of the read-out at that concentration, not a potency): -53%
For compound 4 the middle estimate is 22 percentage points below the measured one; measured number outside the range, above it.
By their numbers in this assay, from the lowest: compound 3; then compound 1; then compound 2; then compound 4.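

In this assay, within the data shown here, the group on the carbonyl carbon can shift the read-out more than the earlier compounds showed, with a number 44 percentage points higher from compound 3 to compound 4 (beyond the scatter), the widest gap yet at this position. The two halogenated rings do not behave alike either, with a number 12 percentage points higher from compound 2 to compound 4 (beyond the scatter), while a number 30 percentage points higher from compound 1 to compound 4 (beyond the scatter), which leaves compound 4 with the weakest effect of the four at the one concentration tested. Nothing available here explains these differences.

The compounds shown leave open whether the strong effect of compound 3 depends on having both methoxy groups, which a ring with a single methoxy group or a plain phenyl ring could help test. They also leave open how a ring carrying a carboxylic acid would behave, and how these compounds would rank at lower concentrations.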